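From thiophen-3-yl to furan-2-yl in compound 2

The source may hold more compounds than are shown below. What is called first, only, known or untested is meant among the compounds shown, and "the series" means these compounds.

In a functional assay on SK-MEL-2 cells (Homo sapiens) for antiproliferative activity (on this read-out lower numbers stand for stronger inhibition of growth and higher numbers for weaker inhibition of growth), compound 2 `c1ccc(-c2cc(-c3ccsc3)cc(-c3ccccn3)n2)nc1` gives 0.89 ug/mL, the lower of the two numbers, while compound 1 `c1ccc(-c2cc(-c3cccnc3)nc(-c3ccccn3)c2)cc1` gives 89.2 ug/mL. Compound 3 `c1ccc(-c2cc(-c3ccsc3)cc(-c3cccnc3)n2)nc1` gives > 100 ug/mL, which is a limit. Compound 4 `c1ccc(-c2cc(-c3ccco3)cc(-c3ccccn3)n2)nc1` differs from compound 2 by furan-2-yl in place of thiophen-3-yl on an aromatic carbon. Within the data shown here, two measured steps bear on this. Thiophen-3-yl in place of phenyl gave an at least 1.1-fold higher number from compound 1 to compound 3 (0.04 log units; that floor lies within the scatter), a step that ends at the limit of > 100 ug/mL in this assay, at which 1 of the 3 values shown sits. Pyridin-3-yl in place of pyridin-2-yl gave an at least 110-fold higher number from compound 2 to compound 3 (2.05 log units; beyond the scatter), but compound 4 keeps both pyridin-2-yl groups. No step beyond the scatter is therefore expected, and the expected change is a 1.7-fold higher number from compound 2 to compound 4 (0.23 log units; within the scatter). Compound 4 is estimated at 1.5 ug/mL, with an expected range of 0.3 ug/mL to 8 ug/mL.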

Compound 4, concentration for 50% growth inhibition: 9.9 ug/mL
Compound 4: middle estimate off by 6.6-fold (0.82 log units), on the low side; the whole stated range lies below it.
By their numbers in this assay, from the lowest: compound 2; then compound 4; then compound 1. At a limit, above all of these: compound 3.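

In this assay, the position opposite the ring nitrogen responds strongly to which five-membered aromatic ring it carries: an 11-fold higher number from compound 2 to compound 4 (1.05 log units; beyond the scatter). Among these compounds, until now, the only large step with a readable direction was the change from pyridin-2-yl to pyridin-3-yl; here both pyridin-2-yl groups stay, and sulfur gives way to oxygen in a ring of equal heavy-atom count. No measurement shown accounts for this step. On these data alone, whether it follows the hetero atom or the point of attachment remains open, and a thiophen-2-yl group would separate the two. As far as these compounds go, how an amine at this position would fare also remains open.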